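Cytotoxicity notes on an amide series: compound 4 from compound 1

The source may report more compounds than this note shows. Statements on the series, on what has been measured and on what is new or still open speak of the compounds shown alone.

Measured so far in a functional assay on MCF7 cells (Homo sapiens) for cytotoxicity, read by MTT assay, with a stated time of 24 h, tested at 1.6 ug/mL; on this read-out higher numbers stand for a stronger effect at the one concentration tested and lower numbers for a weaker effect:
compound 1 `Cn1c(-c2ccc(NC(=O)CSc3nc4cc(Cl)ccc4o3)cc2)nc(-c2ccccc2)c1-c1ccccc1` gives 2.5%
compound 2 `Cn1c(-c2ccc(NC(=O)CSc3nc4ccccc4s3)cc2)nc(-c2ccccc2)c1-c1ccccc1` gives 2.1%
compound 3 `Cn1cnnc1SCC(=O)Nc1ccc(-c2nc(-c3ccccc3)c(-c3ccccc3)n2C)cc1` gives 42.8%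

Compound 1 stands second highest of the three numbers, with compound 2 within the scatter of it (a number 0.4 percentage points lower from compound 1 to compound 2 (within the scatter)) and compound 3 far beyond it (a number 40.3 percentage points higher from compound 1 to compound 3 (beyond the scatter)).

Compound 4 `CN(C)/C=C/N1CCN(CC(=O)Nc2ccc(-c3nc(-c4ccccc4)c(-c4ccccc4)n3C)cc2)CC1` is unmeasured. Its difference from compound 1 is 4-(2-(dimethylamino)ethenyl)piperazin-1-yl in place of (5-chloro-1,3-benzoxazol-2-yl)sulfanyl on a saturated chain carbon bound to a carbonyl carbon. Among the measured compounds shown here, no measured step covers this exchange; the only steps that bear on a change at the sulfur are a number 40.3 percentage points higher from compound 1 to compound 3 (beyond the scatter) and a number 40.7 percentage points higher from compound 2 to compound 3 (beyond the scatter), both large and upward when the fused bicyclic group left. On that basis an upward step is expected for compound 4, but with wide uncertainty.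

Compound 4 is estimated at 20%, within 3% to 50%.
The expected step is a number 17.5 percentage points higher from compound 1 to compound 4 (beyond the scatter).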

Compound 4, a percentage reported as activity, at one concentration (the size of the read-out at that concentration, not a potency): 1.9%
Beside the measured number, compound 4's estimate is 18.1 percentage points above it, outside the stated range (below it).
By their numbers in this assay, from the lowest: compounds 4, 2 and 1 (each within the scatter of the next); then compound 3.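

In this assay, 4-(2-(dimethylamino)ethenyl)piperazin-1-yl on the saturated chain carbon gives a number 0.6 percentage points lower from compound 1 to compound 4 (within the scatter) and a number 0.2 percentage points lower from compound 2 to compound 4 (within the scatter) so this sulfur-free group stands level with both fused bicyclic sulfanyl groups. The same exchange gives a number 40.9 percentage points lower from compound 3 to compound 4 (beyond the scatter) so losing the fused bicyclic group does not itself bring a high number, and among these four compounds only compound 3 reaches one. No evidence on the cause of these differences is at hand.

On these data alone, it remains open whether the number of compound 3 depends on the sulfur link or on the triazole. An imidazol-2-ylsulfanyl group or a plain dimethylamino group at this place would help separate the two.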